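Chain amine swap on the shared core, growth inhibition series

This account rests on a few compounds, and the source may have more. Where it says the series, first, only, none or still open, it means among the compounds named here.

Compound 1 `CCCCNc1ccnc2cc(Cl)ccc12` is the reference point. In a functional assay on 184B5 cells (Homo sapiens) for cytotoxicity, read by sulforhodamine B assay, with a stated time of 48 h (a lower number here means a stronger inhibitor of growth, a higher number a weaker inhibitor of growth), compound 1 gives 18400 nM. Among the measured compounds shown here, compound 2 `CCCCNc1ccnc2cc(F)ccc12` is its only measured neighbour; in this assay compound 2 gives 18700 nM. For the measured compounds named here, the one measured step, a 1.0-fold higher number from compound 1 to compound 2 (0.01 log units; within the scatter), is fluoro in place of chloro on an aromatic carbon, and it leaves the number essentially unchanged; compound 1 and compound 2 therefore stand together within the scatter, and neither can be called the stronger.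

Compound 3 `CN(C)CCNc1ccnc2cc(Cl)ccc12` is not yet measured. Relative to compound 1 the change is dimethylamino in place of ethyl on a saturated chain carbon, two bonds along the chain from a nitrogen on an aromatic ring. Going by the values given here, no measured step touches the chain; the halogen swap on the aromatic ring says nothing about this position. Among the compounds with values here, with no bearing step in hand, no shift beyond the scatter is expected in this assay, in either direction, though the range is kept wide. Compound 3 is expected at 15000 nM, between 5000 nM and 45000 nM. The estimated step of a 1.2-fold lower number from compound 1 to compound 3 (0.09 log units; within the scatter) is thus expected to lie close to the scatter.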

Compound 3, concentration for 50% growth inhibition: 44500 nM
Compound 3: middle estimate off by 3.0-fold (0.47 log units), on the low side; the range from low to high includes it.
By their numbers in this assay, from the lowest: compounds 1 and 2 (each within the scatter of the next); then compound 3.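

Among the compounds shown here, the chain position is the first place where a change moves the number. In this assay, dimethylamino in place of ethyl on a saturated chain carbon, two bonds along the chain from a nitrogen on an aromatic ring, gives (a 2.4-fold higher number from compound 1 to compound 3 (0.38 log units; beyond the scatter)), a modest step beyond the scatter towards weaker inhibition of growth, whereas the halogen swap on the aromatic ring gave no shift that could be read. A single step cannot separate the contribution of the added nitrogen from that of the larger group, and nothing measured here accounts for the loss at this position.

Open, going by these compounds, is whether the shift follows the nitrogen itself, which a chain ending in a primary amine, a piperidine or a morpholine at the same place could test, and whether moving dimethylamino further out on a longer chain changes the size of the step. Also open, on these data alone, is whether the 2-(dimethylamino)ethyl chain gives a similar step on the fluoro core of compound 2.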